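Chain length in the hydroxycarbamoyl series: outlook for compound 3

The source may report more compounds than this note shows. Statements on the series, on what has been measured and on what is new or still open speak of the compounds shown alone.

- compound 1 `Nc1ncnc2c1c(-c1cnc3[nH]ccc3c1)nn2CCCCCCCCC(=O)NO` gives 24700 nM
- compound 2 `Nc1ncnc2c1c(-c1cnc3[nH]ccc3c1)nn2CCCCCCCCCC(=O)NO` gives 23200 nM

Both values come from a functional assay on MCF7 cells (Homo sapiens) for inhibition, read by MTT assay, with a stated time of 72 h; on this read-out higher numbers stand for weaker inhibition and lower numbers for stronger inhibition. Among the compounds with values here, the only measured step is a 1.1-fold lower number from compound 1 to compound 2 (0.03 log units; within the scatter), so compound 2 stands level with the one other measured compound, with nothing separating them.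

Next in the series is compound 3 `Nc1ncnc2c1c(-c1cnc3[nH]ccc3c1)nn2CCCCCCC(=O)NO`, which has a shorter chain on the shared core: hydroxycarbamoyl in place of 3-(hydroxycarbamoyl)propyl on a saturated chain carbon, six bonds along the chain from an aromatic nitrogen. In words, this is hydroxycarbamoyl in place of 3-(hydroxycarbamoyl)propyl on a saturated chain carbon, six bonds along the chain from an aromatic nitrogen.

Within the data shown here, the single measured chain step, a 1.1-fold lower number from compound 1 to compound 2 (0.03 log units; within the scatter), is the only evidence bearing on this change. It is a smaller change, made eight bonds along the chain. No chain shorter than that of compound 1 has been measured, so its flat result may not carry over. No step beyond the scatter is expected in this assay, but the range is kept wide. The expected step is a 1.2-fold lower number from compound 2 to compound 3 (0.06 log units; within the scatter). For compound 3 the estimated value is 20000 nM, with an expected range of 7000 nM to 50000 nM.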

Compound 3, half-maximal inhibitory concentration: 19800 nM
The estimate for compound 3 lay 1.0-fold (0.00 log units) above the measured number, within the range that was stated.
By their numbers in this assay, from the lowest: compounds 3, 2 and 1 (each within the scatter of the next).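

Replacing 3-(hydroxycarbamoyl)propyl with hydroxycarbamoyl, six bonds along the chain from an aromatic nitrogen, gives a 1.2-fold lower number from compound 2 to compound 3 (0.07 log units; within the scatter) in this assay and leaves the series flat, and replacing 2-(hydroxycarbamoyl)ethyl with hydroxycarbamoyl at the same place gives the wider comparison (a 1.2-fold lower number from compound 1 to compound 3 (0.10 log units; within the scatter)). The flat result therefore no longer rests on a single step: it now reaches a chain shorter than either earlier one and also holds across the larger difference in chain length, so no chain length in the series separates from the others. No measurement at hand accounts for this lack of separation.

Still open, from the compounds shown here alone, is whether a chain shorter than hydroxycarbamoyl on this saturated chain carbon, or a longer chain than that of the longest compound here, would stay level with these three in this assay as well. Also open, going by these compounds, is whether an amine or a carboxylic acid in place of the hydroxycarbamoyl end would give a step beyond the scatter, which would show whether that end group matters at all on this read-out.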